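This account rests on a few compounds, and the source may have more. Where it says the series, first, only, none or still open, it means among the compounds named here.

Compound 1, `[O-]/[N+](=C\c1cn(-c2ccccc2)nn1)c1ccccc1`: in a functional assay on MDA-MB-231 cells (Homo sapiens) for inhibition, read by MTT assay, with a stated time of 24 h (a lower number here means a stronger inhibitor, a higher number a weaker inhibitor), compound 1 gives > 100000 nM, which is a limit of the assay and not a number.
Compound 2, `[O-]/[N+](=C\c1cn(-c2ccccc2)nn1)Cc1ccccc1`: in this assay compound 2 gives > 100000 nM, again a limit of the assay.
Compound 3, `CC(C)(C)/[N+]([O-])=C/c1cn(-c2ccccc2)nn1`: in this assay compound 3 gives 14800 nM.

Compound 3 therefore stands as the only one of the three with a measured number; the other two sit at the limit of > 100000 nM in this assay, at which 2 of the 3 values shown sit. Exchanging the phenyl or the benzyl on the double-bonded nitrogen for tert-butyl gave an at least 6.7-fold lower number from compound 1 to compound 3 (0.82 log units; beyond the scatter) and an at least 6.7-fold lower number from compound 2 to compound 3 (0.82 log units; beyond the scatter). Between compound 1 and compound 2 the step is a step that the two limits leave unreadable from compound 1 to compound 2.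

Compound 4, `COc1ccc(-n2cc(/C=[N+](\[O-])C(C)(C)C)nn2)cc1`, differs from compound 3 by methoxy in place of hydrogen on an aromatic carbon. Among the compounds with values here, none of the measured steps touches this ring; all of them alter the group on the double-bonded nitrogen, which compound 4 keeps as tert-butyl. Within the data shown here, no measured step bears directly on this change, and the expected step is a 1.1-fold lower number from compound 3 to compound 4 (0.06 log units; within the scatter), that is, none beyond the scatter. Compound 4 is thus estimated at 13000 nM, with a range from 4000 nM to 45000 nM.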

Compound 4, half-maximal inhibitory concentration: 23100 nM
Compound 4: middle estimate off by 1.8-fold (0.25 log units), on the low side; measured number inside the range.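

Within the data shown here, compound 4 moves the change for the first time away from the group on the double-bonded nitrogen, to the six-membered aromatic ring of carbon only, para to a large group. In this assay, methoxy in place of hydrogen at this position gives a 1.6-fold higher number from compound 3 to compound 4 (0.19 log units; within the scatter), so this one change leaves the number with no shift that can be told from the scatter, whereas exchanging the group on the double-bonded nitrogen did go beyond it. Both ends of this step are real numbers, while compound 1 and compound 2 remain a limit and not a number: the limit of > 100000 nM in this assay, at which 2 of the 4 values shown sit.

Only methoxy is shown at this position, so whether an amine, a carboxylic acid or a longer chain would be accepted there stays open. Also open, going by these compounds, is whether methoxy would behave the same elsewhere on this ring.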